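Methyl in place of chloro: working notes on compound 4

The source may hold more compounds than are shown below. What is called first, only, known or untested is meant among the compounds shown, and "the series" means these compounds.

Measured in a functional assay on U-251 cells (Homo sapiens) for antiproliferative activity, read by MTT assay, with a stated time of 48 h; on this read-out lower numbers stand for stronger inhibition and higher numbers for weaker inhibition:
- compound 1 `COc1ccc(-c2nc3cccc(-c4cc(OC)c(OC)c(OC)c4)c3o2)cc1OC`: 1300 nM
- compound 2 `COc1cc(-c2cccc3nc(-c4ccc(Br)cc4)oc23)cc(OC)c1OC`: > 25000 nM, a limit
- compound 3 `COc1cc(-c2cccc3nc(-c4ccc(Cl)cc4)oc23)cc(OC)c1OC`: 1600 nM

Compound 3 sits within the scatter of compound 1, as a 1.2-fold higher number from compound 1 to compound 3 (0.09 log units; within the scatter) shows. Compound 4 `COc1cc(-c2cccc3nc(-c4ccc(C)cc4)oc23)cc(OC)c1OC` differs from it by methyl in place of chloro on an aromatic carbon, para to a large group. Among the measured compounds shown here, two steps bear on this. The large at least 15-fold lower number from compound 2 to compound 3 (1.19 log units; beyond the scatter) shows that one exchange at this place can matter greatly, while a 1.2-fold higher number from compound 1 to compound 3 (0.09 log units; within the scatter) shows that a different group there can leave the number unmoved. In this assay, no step beyond the scatter is therefore expected, though the risk leans towards a higher number. The expected change is a 1.3-fold higher number from compound 3 to compound 4 (0.10 log units; within the scatter). Compound 4 is estimated at 2000 nM, with an expected range of 600 nM to 9000 nM.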

Compound 4, half-maximal inhibitory concentration: 3200 nM
Compound 4: the middle estimate sits 1.6-fold (0.20 log units) below what was measured; the measured number falls inside the stated range.
By their numbers in this assay, from the lowest: compounds 1, 3 and 4 (each within the scatter of the next, the first and the last beyond it). At a limit, above all of these: compound 2.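

In this assay, methyl in place of chloro gives a 2.0-fold higher number from compound 3 to compound 4 (0.30 log units; within the scatter), so this position takes either small group without a step beyond the scatter. Replacing 3,4-dimethoxyphenyl with 4-methylphenyl gives a 2.5-fold higher number from compound 1 to compound 4 (0.39 log units; beyond the scatter), a modest step, whereas 4-chlorophenyl gave a 1.2-fold higher number from compound 1 to compound 3 (0.09 log units; within the scatter). Methyl in place of bromo gives an at least 7.8-fold lower number from compound 2 to compound 4 (0.89 log units; beyond the scatter), which leaves bromo as the one sharp departure, and compound 2 stands at a limit: the limit of > 25000 nM in this assay, at which 1 of the 4 values shown sits.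

The compounds shown leave open how an amine, a carboxylic acid or a longer chain would read at this place. They also do not settle why bromo parts so far from chloro and methyl.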